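A few compounds are considered here, and "the series" means these few. Any claim that something is new, unique, unknown or untested is made for them only; others in the source may bear on it.

Compound 1 `CCCCCCCCOP(=O)(O)OCCSC(=S)N1CCCC1`, compound 2 `CCCCCCCCOP(=O)(O)OCCSC(=S)N1CCCCC1` and compound 3 `CCCCCCCCOP(=O)(O)OCCSC(=S)N1CCN(C)CC1` share one core and differ only in the group on the thiocarbonyl carbon. In a functional assay on DU-145 cells (Homo sapiens) for inhibition, read by MTT assay, with stated times of 18 h and 4 h (a higher number here means a weaker inhibitor, a lower number a stronger inhibitor), compound 1 gives 47100 nM. Compound 2 gives > 100000 nM, which is a limit of the assay and not a number. Compound 3 gives > 100000 nM, which is also a limit. Compound 2 therefore stands at the limit of > 100000 nM in this assay, at which 2 of the 3 values shown sit.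

The measured steps are an at least 2.1-fold higher number from compound 1 to compound 2 (0.32 log units; beyond the scatter) and an at least 2.1-fold higher number from compound 1 to compound 3 (0.32 log units; beyond the scatter). Both lie beyond the scatter, while a step that the two limits leave unreadable from compound 2 to compound 3 cannot be read.

Compound 4 `CCCCCCOP(=O)(O)OCCSC(=S)N1CCCCC1` departs from compound 2 by hydrogen in place of ethyl on a saturated chain carbon, six bonds along the chain from an oxygen on an unsaturated carbon. Going by the values given here, none of the measured steps alters this chain, so they bear on the new change only indirectly and give it no size. No step beyond the scatter is therefore expected in this assay, in either direction. This expectation starts from compound 2, whose > 100000 nM is only a limit, and compound 4 may well be reported as a limit too. The expected change is a number no higher from compound 2 to compound 4 (the limit leaves the size open). For compound 4 the estimated value is 100000 nM, with an expected range from 40000 nM to 250000 nM.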

Compound 4, half-maximal inhibitory concentration: > 100000 nM
Compound 4: a limit, no number (the forecaster's own chance of this, stated with the estimate: 70%); the middle value sits exactly at the limit.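

Compound 4 gives > 100000 nM in this assay, which is a limit and not a number. Compound 2 also stands at a limit, and the step between compound 2 and compound 4 cannot be read. The compounds shown leave open whether hydrogen in place of ethyl on this chain changes inhibition at all.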